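Difluorophenyl placement on the acylurea of a thiazole series

A few compounds are considered here, and "the series" means these few. Any claim that something is new, unique, unknown or untested is made for them only; others in the source may bear on it.

Measured so far:
compound 1 `CN(C(=O)NC(=O)c1ccc(F)c(F)c1)c1nc(C(F)(F)F)c(C(=O)N/N=C/c2ccc(C(F)(F)F)cc2)s1` — 5.1 ug/mL
compound 2 `CN(C(=O)NC(=O)c1ccc(F)c(F)c1)c1nc(C(F)(F)F)c(C(=O)N/N=C/c2cccc(C(F)(F)F)c2)s1` — 4.21 ug/mL
compound 3 `CN(C(=O)NC(=O)c1ccc(F)c(F)c1)c1nc(C(F)(F)F)c(C(=O)N/N=C/c2ccc([N+](=O)[O-])cc2)s1` — 5.08 ug/mL

In a functional assay on HeLa cells (Homo sapiens) for inhibition, read by MTT assay, with a stated time of 72 h (on this read-out lower numbers stand for stronger inhibition and higher numbers for weaker inhibition), compound 1 gives 5.1 ug/mL; its steps to the two other compounds, a 1.2-fold lower number from compound 1 to compound 2 (0.08 log units; within the scatter) and a 1.0-fold lower number from compound 1 to compound 3 (0.00 log units; within the scatter), both stay within the scatter, so the three values cannot be told apart. Compound 4 `CN(C(=O)NC(=O)c1c(F)cccc1F)c1nc(C(F)(F)F)c(C(=O)N/N=C/c2ccc(C(F)(F)F)cc2)s1` differs from compound 1 only on the acyl side: 2,6-difluorophenyl in place of 3,4-difluorophenyl on a carbonyl carbon. Among the measured compounds shown here, none of the measured steps touches that ring; all three vary the aryl on the hydrazone side, and each of them was within the scatter. For the measured compounds named here, there is thus no measured step that bears on the change from compound 1 to compound 4, and no direction beyond the scatter can be expected. The estimate for compound 4 is therefore 5 ug/mL, within 2 ug/mL to 12.5 ug/mL, meaning an expected step of a 1.0-fold lower number from compound 1 to compound 4 (0.01 log units; within the scatter).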

Compound 4, half-maximal inhibitory concentration: 30.6 ug/mL
Beside the measured number, compound 4's estimate is 6.1-fold (0.79 log units) below it, outside the stated range (above it).
By their numbers in this assay, from the lowest: compounds 2, 3 and 1 (each within the scatter of the next); then compound 4.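

In this assay, among the compounds shown here, the aryl on the carbonyl carbon is the first place where a change registers, toward weaker inhibition: a 6.0-fold higher number from compound 1 to compound 4 (0.78 log units; beyond the scatter). The two groups hold the same atoms, so rearranging the fluorines on that ring is enough to separate the compounds, whereas the hydrazone-side changes stayed within the scatter. Nothing available here accounts for this shift.

On these data alone, whether 2,6-difluorophenyl costs as much alongside the hydrazone aryls of compound 2 and compound 3 remains open. So does how an unsubstituted phenyl or a pyridine ring on that carbonyl carbon would read.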